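Cycloheptyl Replaces Propyl in a Bombesin Receptor Subtype-3 Agonist

The source may report more compounds than this note shows. Statements on the series, on what has been measured and on what is new or still open speak of the compounds shown alone.

Measured compounds:
compound 1 `CC(C)(C)Cc1cnc(CCc2ccc(-c3ccccc3C(=O)O)cc2)[nH]1` gives 106 nM
compound 2 `CCCCc1cnc(CCc2ccc(-c3ccccc3C(=O)O)cc2)[nH]1` gives 2710 nM

Among the measured compounds shown here, in an in vitro functional assay on cells for agonist activity at Bombesin receptor subtype-3 (Homo sapiens), read by luminescence and calcium flux (on this read-out higher numbers stand for an effect only at larger amounts of compound and lower numbers for an effect already at smaller amounts), compound 2 stands highest of the two numbers, with compound 1 as its only neighbour, a far lower number. Compound 3 `O=C(O)c1ccccc1-c1ccc(CCc2ncc(CC3CCCCCC3)[nH]2)cc1` differs from compound 2 by cycloheptyl in place of propyl on a saturated chain carbon bound to an aromatic carbon. For the measured compounds named here, the one measured step that bears on this is a 26-fold higher number from compound 1 to compound 2 (1.41 log units; beyond the scatter), which was large and went toward higher numbers when the branched group gave way to propyl. A return to a larger group is therefore expected to bring a lower number, a 14-fold lower number from compound 2 to compound 3 (1.13 log units; beyond the scatter). For compound 3 the estimate is 200 nM, within 50 nM to 800 nM.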

Compound 3, half-maximal effective concentration: 88 nM
Compound 3: the middle estimate sits 2.3-fold (0.36 log units) above what was measured; measured number inside the range.
By their numbers in this assay, from the lowest: compounds 3 and 1 (each within the scatter of the next); then compound 2.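

In this assay cycloheptyl at this saturated chain carbon gives a 31-fold lower number from compound 2 to compound 3 (1.49 log units; beyond the scatter) and so shows that this place accepts a seven-membered ring and not only a branched group. Set against tert-butyl, the same change gives a 1.2-fold lower number from compound 1 to compound 3 (0.08 log units; within the scatter) so the ring and the branched group cannot be told apart on this read-out, and propyl alone stands apart among the three. Going by these compounds, whether cyclopentyl, phenyl or a tetrahydropyranyl ring would hold this level remains open. Nothing given here accounts for the gap between propyl and the other two groups.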